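Tolyl for fluorophenyl, repeated on a second core

The compounds below may be only part of what the source reports. "The series", "measured", "known", "first", "only" and "open" are said of these compounds alone.

Measured compounds:
compound 1, `Cc1cc(=O)n(-c2cccc(F)c2)nc1C(=O)Nc1ccc(Oc2ncnc3[nH]ccc23)cc1`, 3180 nM
compound 2, `Cc1ccc(-n2nc(C(=O)Nc3ccc(Oc4ncnc5[nH]ccc45)cc3)c(C)cc2=O)cc1`, 7460 nM
compound 3, `Cc1cc(=O)n(-c2cccc(F)c2)nc1C(=O)Nc1ccc(Oc2ncnc3c2ccn3C)c(F)c1`, > 60000 nM (a limit of the assay, not a number)

The study follows one structural change across two cores. In a functional assay on HepG2 cells (Homo sapiens) for cytotoxicity, read by MTT assay, with a stated time of 72 h (on this read-out higher numbers stand for weaker inhibition and lower numbers for stronger inhibition), compound 1 gives 3180 nM. Compound 2 differs from it in a single place, (4-methylphenyl in place of 3-fluorophenyl on an aromatic nitrogen), and this move gives a 2.3-fold higher number from compound 1 to compound 2 (0.37 log units; beyond the scatter). Compound 3 carries a different core; how the core of compound 3 differs from the core of compound 1 is not broken down here. In this assay compound 3 reports only a limit, > 60000 nM.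

Compound 4, `Cc1ccc(-n2nc(C(=O)Nc3ccc(Oc4ncnc5c4ccn5C)c(F)c3)c(C)cc2=O)cc1`, is not yet measured. It stands to compound 3 exactly as compound 2 stands to compound 1: 4-methylphenyl in place of 3-fluorophenyl on an aromatic nitrogen, the same change at the same place. The earlier pair shows that this change raises the number by a modest step, a 2.3-fold higher number from compound 1 to compound 2 (0.37 log units; beyond the scatter). Because compound 3 already sits at the limit (the limit of > 60000 nM in this assay, at which 1 of the 3 values shown sits), a further rise cannot be resolved by the assay, and compound 4 is expected to report a limit as well. The step estimated here is a step that the limit leaves unreadable from compound 3 to compound 4, placed beside a 2.3-fold higher number from compound 1 to compound 2 (0.37 log units; beyond the scatter), and it rests only on that one earlier pair. Compound 4 is thus estimated at 120000 nM in this assay, with the range from 60000 nM to 300000 nM.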

Compound 4, half-maximal inhibitory concentration: > 60000 nM
Compound 4: a limit, no number; the forecaster's own chance of this, stated with the estimate: 90%; the middle value does not contradict the limit.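

In this assay compound 4 gives > 60000 nM, a limit of the assay and not a number. Compound 3 also reports a limit, and no step can be read from compound 3 to compound 4: the limit of > 60000 nM in this assay, at which 2 of the 4 values shown sit. The compounds shown leave open whether 4-methylphenyl in place of 3-fluorophenyl changes the number at all on the core of compound 3 and, if it does, by how much.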